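Swapping the Amine Tail on a Coumarin-Bearing Pyrazoline

A few compounds are considered here, and "the series" means these few. Any claim that something is new, unique, unknown or untested is made for them only; others in the source may bear on it.

Measured compounds:
- compound 1, `CC1=NN(S(=O)(=O)c2ccc(C)cc2)C(c2cc(Br)cc(Br)c2O)C1`: 51200 nM
- compound 2, `CC(=O)Oc1ccccc1C1CC(C)=NN1C(=O)CN1CCC(C(C)=O)CC1`: 6800 nM
- compound 3, `CCNCC(=O)N1N=C(c2cc3ccccc3oc2=O)CC1c1ccccc1`: 5580 nM

All three were tested in a functional assay on PC-3 cells (Homo sapiens) for cytotoxicity, read by MTT assay, with a stated time of 48 h; on this read-out higher numbers stand for weaker inhibition and lower numbers for stronger inhibition. Compound 3 gives the lowest of the three numbers, with 5580 nM. Its nearest neighbour is compound 2, whose value of 6800 nM lies within the usual scatter of such measurements, so the two cannot be told apart. Compound 1 stands clearly apart at 51200 nM, a gap beyond the scatter.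

The next compound keeps the core of compound 3 and changes only the tail on the amide side chain. Compound 4, `O=C(CN1CCC(O)CC1)N1N=C(c2cc3ccccc3oc2=O)CC1c1ccccc1`, differs as follows: 4-hydroxypiperidin-1-yl in place of ethylamino on a saturated chain carbon bound to a carbonyl carbon. The ring that enters is a saturated six-membered ring carrying a hydroxyl group, replacing a short open-chain amine.

Among the compounds with values here, no pair of measured compounds differs in exactly this way, so no measured step is available to lean on. The closest hint is compound 2, which also carries a piperidine on the same kind of chain and sits within the scatter of compound 3. The step of a 1.0-fold lower number from compound 3 to compound 4 (0.01 log units; within the scatter) is therefore expected to be small, in no firm direction, and likely within the scatter. Compound 4 is estimated at 5500 nM, with a plausible range from 2000 nM to 16000 nM.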

Compound 4, half-maximal inhibitory concentration: "not active" (no number reported)
No number was reported for compound 4, and the estimate cannot be compared.
By their numbers in this assay, from the lowest: compounds 3 and 2 (each within the scatter of the next); then compound 1.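

In this assay, within the data shown here, compound 4 is reported only as "not active", with no number, so no step from compound 3 to compound 4 can be read. The compounds shown leave open how far, in numbers, 4-hydroxypiperidin-1-yl in place of ethylamino shifts the result. Nothing available here explains this outcome.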